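Ethyl for trifluoromethyl on an indole fatty acid receptor agonist

The compounds below may be only part of what the source reports. "The series", "measured", "known", "first", "only" and "open" are said of these compounds alone.

Among the measured compounds shown here, compound 2 `O=C(O)CCc1ccc2[nH]c(-c3ccccc3C(F)(F)F)cc2c1` is the only member of this small group with a numerical result: in a functional assay on CHO cells for agonist activity at Free fatty acid receptor 1 (Homo sapiens), read by a luciferase reporter, with a stated time of 24 h (a higher number here means that more compound is needed for the effect, a lower number that less compound is needed), compound 2 gives 1310 nM. Compound 1 `Cn1c(-c2ccccc2Br)cc2cc(CCC(=O)O)ccc21` reaches only a limit of this assay, > 10000 nM. Compound 3 `COc1cccc(-c2cc3cc(CCC(=O)O)ccc3[nH]2)c1` likewise gives only a limit in this assay, > 25 nM. Compound 4 `CCc1ccccc1-c1cc2cc(CCC(=O)O)ccc2[nH]1` carries ethyl in place of trifluoromethyl on an aromatic carbon. For the measured compounds named here, no two measured compounds differ in a single place, so the size of such a change cannot be read from these data, and the step expected from compound 2 to compound 4 in this assay is a 1.3-fold lower number from compound 2 to compound 4 (0.12 log units; within the scatter), not beyond the usual scatter. Compound 4 is therefore estimated at 1000 nM in this assay, with a range from 300 nM to 4000 nM.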

Compound 4, half-maximal effective concentration: 1800 nM
The estimate for compound 4 lay 1.8-fold (0.26 log units) below the measured number, within the range that was stated.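

Among the compounds shown here, putting ethyl in place of trifluoromethyl gives a 1.4-fold higher number from compound 2 to compound 4 (0.14 log units; within the scatter) in this assay, the first comparison here between compounds that differ in one place. On this aromatic carbon, ortho to a large group, the two groups cannot be told apart, even though 4 heavy atoms leave and 2 enter. Nothing among the data shown bears on why they read alike.

As far as these compounds go, whether an amine or a longer chain on this carbon would give a similar number remains open. So does whether a carboxylic acid there would be tolerated.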